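The source may hold more compounds than are shown below. What is called first, only, known or untested is meant among the compounds shown, and "the series" means these compounds.

Compound 1 `Clc1ccc2c(N/N=C/c3cnc[nH]3)ccnc2c1`: 29.1 uM
Compound 2 `Cn1cncc1/C=N/Nc1ccnc2cc(Cl)ccc12`: 73.8 uM

In a functional assay on KB cells (Homo sapiens) for cytotoxicity (on this read-out lower numbers stand for an effect already at smaller amounts and higher numbers for an effect only at larger amounts of compound), compound 2 has the higher of the two numbers, at 73.8 uM. Compound 3 `Clc1ccc2c(N/N=C/c3ncc[nH]3)ccnc2c1` is not yet measured. It carries 1H-imidazol-2-yl in place of 1-methyl-1H-imidazol-5-yl on a carbon with a double bond to nitrogen. Among the measured compounds shown here, one measured step bears on this change, a modest one: a 2.5-fold higher number from compound 1 to compound 2 (0.40 log units; beyond the scatter), with methyl in place of hydrogen on an aromatic nitrogen. For the measured compounds named here, compound 3 has no such methyl, but its imidazole is attached differently, and no measured step covers that. A similar modest shift towards a lower number is therefore expected, a 2.3-fold lower number from compound 2 to compound 3 (0.36 log units; beyond the scatter). For compound 3 the estimated value is 32 uM, with an expected range from 11 uM to 85 uM.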

Compound 3, concentration for half-maximal effect: 19.5 uM
Compound 3: the middle estimate sits 1.6-fold (0.22 log units) above what was measured; the range from low to high includes it.
By their numbers in this assay, from the lowest: compounds 3 and 1 (each within the scatter of the next); then compound 2.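

In this assay, the step of a 1.5-fold lower number from compound 1 to compound 3 (0.17 log units; within the scatter) means that moving the attachment point of the unmethylated imidazole gives two compounds that cannot be told apart. The step of a 3.8-fold lower number from compound 2 to compound 3 (0.58 log units; beyond the scatter) shows that 1H-imidazol-2-yl on this carbon with a double bond to nitrogen gives a number clearly lower than 1-methyl-1H-imidazol-5-yl does. Nothing measured here explains this difference. As far as these compounds go, it remains open whether a methyl on the ring nitrogen of 1H-imidazol-2-yl would raise the number too. From the compounds shown here alone, how a pyridine or an aminoethyl chain would behave in this place also remains open.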